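Moving a Hydroxyl Group at the Assay Limit

The source may report more compounds than this note shows. Statements on the series, on what has been measured and on what is new or still open speak of the compounds shown alone.

Compound 3 `Oc1cccc(-c2cc(-c3ccc(C(F)(F)F)cc3)cc(-c3ccccc3O)n2)c1` was tested in a functional assay on HeLa cells (Homo sapiens) for inhibition; a lower number here means a stronger inhibitor, a higher number a weaker inhibitor. In this assay compound 3 gives only a limit, > 50000 nM. Compound 1 `Oc1cccc(-c2cc(-c3ccc(F)cc3)cc(-c3ccccc3O)n2)c1` likewise gives only a limit in this assay, > 50000 nM. Compound 2 `Oc1cccc(-c2cc(-c3ccccc3C(F)(F)F)cc(-c3ccccc3O)n2)c1` gives 16800 nM in this assay. The step of an at least 2.9-fold lower number from compound 1 to compound 2 (0.47 log units; beyond the scatter) and the step of an at least 2.9-fold higher number from compound 2 to compound 3 (0.47 log units; beyond the scatter) both alter the group on the other aromatic carbon of the shared core, not the hydroxyphenyl groups, and the step that the two limits leave unreadable from compound 1 to compound 3 cannot be sized because of the limit of > 50000 nM in this assay, at which 2 of the 3 values shown sit.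

Compound 4 `Oc1ccc(-c2cc(-c3ccc(C(F)(F)F)cc3)cc(-c3cccc(O)c3)n2)cc1` differs from compound 3 by 4-hydroxyphenyl in place of 2-hydroxyphenyl on an aromatic carbon. Within the data shown here, none of the measured steps touches a hydroxyphenyl group, so no measured step bears directly on this change, and compound 3 itself stands only at a limit. Compound 4 is therefore expected to remain at or near that limit, and the expected step is a number no higher from compound 3 to compound 4 (the limit leaves the size open). Compound 4 is estimated to give 50000 nM in this assay, within a range from 15000 nM to 100000 nM.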

Compound 4, half-maximal inhibitory concentration: 17300 nM
Estimate against measurement, compound 4: 2.9-fold (0.46 log units) above; the measured number falls inside the stated range.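

In this assay the change to 4-hydroxyphenyl from 2-hydroxyphenyl gives an at least 2.8-fold lower number from compound 3 to compound 4 (0.46 log units; beyond the scatter) and so shows that the group next to the ring nitrogen can move the number. The earlier readable steps altered only the group on the other aromatic carbon, whereas here the 4-(trifluoromethyl)phenyl group stays and the two compounds have the same atoms, joined differently. As far as these compounds go, the full size of this step stays open because compound 3 stands only at a limit: the limit of > 50000 nM in this assay, at which 2 of the 4 values shown sit.

From the compounds shown here alone, whether 4-hydroxyphenyl would lower the number in the same way with 2-(trifluoromethyl)phenyl on the other carbon remains open. So does what an amine or a methoxy group would do in place of the hydroxyl at this position.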